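A few compounds are considered here, and "the series" means these few. Any claim that something is new, unique, unknown or untested is made for them only; others in the source may bear on it.

In a functional assay on A549 cells (Homo sapiens) for antiproliferative activity, read by MTT assay, with a stated time of 72 h (a higher number here means a weaker inhibitor, a lower number a stronger inhibitor), compound 3 `NC1=NC2(CCOCC2)N(OCCCOc2cccc(Cl)c2)C(N)=N1` gives 150 nM, the lowest number of the three measured, against compound 2 `Cc1cc(C)cc(OCCCON2C(N)=NC(N)=NC23CCOCC3)c1` at 710 nM and compound 1 `NC1=NC2(CCOCC2)N(OCCCOc2ccccc2)C(N)=N1` at 1080 nM. Compound 4 `Cc1ccc(OCCCON2C(N)=NC(N)=NC23CCOCC3)cc1` has 4-methylphenyl in place of 3-chlorophenyl on an oxygen on a saturated carbon. For the measured compounds named here, two measured steps bear on losing the chloro: a 7.2-fold lower number from compound 1 to compound 3 (0.86 log units; beyond the scatter) and a 4.7-fold lower number from compound 2 to compound 3 (0.68 log units; beyond the scatter). Methyl groups alone gave a 1.5-fold lower number from compound 1 to compound 2 (0.18 log units; within the scatter), within the scatter. Compound 4 has no chloro, so a move to a higher number in this assay is expected, of similar size to those two steps read backwards. The expected step is a 4.7-fold higher number from compound 3 to compound 4 (0.67 log units; beyond the scatter). For compound 4 the estimate is 700 nM, with an expected range of 300 nM to 1500 nM.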

Compound 4, half-maximal inhibitory concentration: 1060 nM
Compound 4: middle estimate off by 1.5-fold (0.18 log units), on the low side; low and high end bracket the measured number.
By their numbers in this assay, from the lowest: compound 3; then compounds 2, 4 and 1 (each within the scatter of the next).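

In this assay, 4-methylphenyl in place of 3-chlorophenyl gives a 7.1-fold higher number from compound 3 to compound 4 (0.85 log units; beyond the scatter), so the chloro-bearing compound 3 stays apart from the methyl-bearing compounds. Against the unsubstituted phenyl, the single methyl gives a 1.0-fold lower number from compound 1 to compound 4 (0.01 log units; within the scatter), and moving from 3,5-dimethylphenyl to 4-methylphenyl gives a 1.5-fold higher number from compound 2 to compound 4 (0.17 log units; within the scatter); among these four compounds, methyl groups on the ring do not separate from phenyl, and only chloro does. Nothing measured here explains this difference. On these data alone, whether bromo or trifluoromethyl on the ring would match chloro remains open. So does the effect of a longer chain between the two oxygens.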